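The source may hold more compounds than are shown below. What is called first, only, known or untested is meant among the compounds shown, and "the series" means these compounds.

Three compounds share one core and differ only in the group on a saturated chain carbon bound to an aromatic carbon and a saturated chain carbon. In a physicochemical assay for solubility, in phosphate buffer, measured as kinetic solubility (on this read-out higher numbers stand for higher solubility and lower numbers for lower solubility), compound 1 `CC(C)C(c1ncc[nH]1)c1ccc(-c2ccc3cccc(F)c3c2)[nH]c1=O` gives 20600 nM, compound 2 `CC(C)C(c1noc(=O)[nH]1)c1ccc(-c2ccc3cccc(F)c3c2)[nH]c1=O` gives 32500 nM, and compound 3 `CC(C)C(Nc1nnc[nH]1)c1ccc(-c2ccc3cccc(F)c3c2)[nH]c1=O` gives 17200 nM. The steps among them are all small: a 1.6-fold higher number from compound 1 to compound 2 (0.20 log units; within the scatter), a 1.2-fold lower number from compound 1 to compound 3 (0.08 log units; within the scatter) and a 1.9-fold lower number from compound 2 to compound 3 (0.28 log units; within the scatter). Compound 3 therefore stands within the scatter of both neighbours, and the three five-membered rings tried so far have not moved this assay noticeably.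

Compound 4 `CC(C)C(Cc1noc(=O)[nH]1)c1ccc(-c2ccc3cccc(F)c3c2)[nH]c1=O` differs from compound 3 in one place: a group of 7 heavy atoms (3 carbon, 2 nitrogen, 2 oxygen; one five-membered aromatic ring with 3 hetero atoms) in place of a group of 6 heavy atoms (2 carbon, 4 nitrogen; one five-membered aromatic ring with 3 hetero atoms), on a saturated chain carbon bound to an aromatic carbon and a saturated chain carbon. The new group is the same ring as in compound 2, now set off from the chain carbon by one more carbon. The step from compound 2 to compound 3 swapped that ring for the triazolylamino group and stayed within the scatter, so reversing the swap, with a carbon added, is expected to do little. For compound 4 the expected number in this assay is 25000 nM, with a range of 12000 nM to 50000 nM, which means a step of a 1.5-fold higher number from compound 3 to compound 4 (0.16 log units; within the scatter) is expected, within the scatter.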

Compound 4, solubility: 30400 nM
The estimate for compound 4 lay 1.2-fold (0.08 log units) below the measured number, within the range that was stated.
By their numbers in this assay, from the lowest: compounds 3, 1, 4 and 2 (each within the scatter of the next).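

Setting the ring of compound 2 one carbon further from the saturated chain carbon gives, in this assay, a 1.1-fold lower number from compound 2 to compound 4 (0.03 log units; within the scatter), so in these two compounds this added carbon leaves the read-out within the scatter. The other two steps, a 1.8-fold higher number from compound 3 to compound 4 (0.25 log units; within the scatter) and a 1.5-fold higher number from compound 1 to compound 4 (0.17 log units; within the scatter), are also within the scatter, so the four groups at this place, with or without a linking carbon or amino nitrogen, cannot be told apart in this assay. No measurement at hand offers a reason for this flat result.

Every group shown contains a five-membered aromatic ring, so it remains open whether a carboxylic acid or a simple amine at this place would also stay within the scatter. From the compounds shown here alone, a longer chain between the ring and the saturated chain carbon is equally open.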